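The source may report more compounds than this note shows. Statements on the series, on what has been measured and on what is new or still open speak of the compounds shown alone.

Compound 1 `Cc1oc(-c2ccc(Cl)c(Cl)c2)nc1CN1CCC(C(=O)NCCCN2C[C@H](C)C[C@H](C)C2)CC1` was studied in an ADME assay on Huh7.5.1 cells (Homo sapiens) for cytotoxicity, read by ATP content, with a stated time of 48 h (a lower number here means that less compound is tolerated, a higher number that more compound is tolerated), where compound 1 gives 3170 nM. Its companion, compound 2 `Cc1ccccc1-c1nc(CN2CCC(C(=O)NCCCN3CCCC(C(C)C)C3)CC2)c(C)o1`, gives 5820 nM in this assay. Of the two numbers shown, that of compound 1 is the lower, but the gap to compound 2 lies within the usual scatter of repeated measurements, so the two compounds cannot be told apart on this evidence.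

Compound 3 `COc1cccc(F)c1-c1nc(CN2CCC(C(=O)NCCCN3C[C@H](C)C[C@H](C)C3)CC2)c(C)o1` has not yet been measured in this assay. It differs from compound 1 in a single place: 2-fluoro-6-methoxyphenyl in place of 3,4-dichlorophenyl on an aromatic carbon. Among the measured compounds shown here, no pair of measured compounds differing in only one place is available, so there is no measured step to lean on. For the measured compounds named here, the only comparison on hand is between compound 1 and compound 2, whose numbers are within scatter of each other, and that comparison involves more than one change.

Given this, compound 3 is expected to show a step of a 1.6-fold higher number from compound 1 to compound 3 (0.20 log units; within the scatter) that is small and, if anything, toward a higher tolerated concentration. The estimate for compound 3 in this assay is 5000 nM, with a range from 2000 nM to 12500 nM.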

Compound 3, half-maximal cytotoxic concentration: 37000 nM
Beside the measured number, compound 3's estimate is 7.4-fold (0.87 log units) below it; the measured number lies above the stated range.
By their numbers in this assay, from the lowest: compounds 1 and 2 (each within the scatter of the next); then compound 3.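

In this assay, among the compounds shown here, putting 2-fluoro-6-methoxyphenyl in place of 3,4-dichlorophenyl gives a 12-fold higher number from compound 1 to compound 3 (1.07 log units; beyond the scatter), and this is the first step between compounds differing in one place that can be read here. It shows that the group on this aromatic carbon of the five-membered ring, next to the ring nitrogen and the ring oxygen, is not a neutral choice for how much compound the cells tolerate. The exchange swaps both chlorine atoms for a fluorine and a methoxy group, adds one hydrogen-bond acceptor and keeps the six-membered aromatic ring, while the rest of compound 1 stays unchanged, so the whole step belongs to this one exchange.

Both substituents change at once, so the compounds shown leave open whether the methoxy group, the fluorine or the removal of the chlorine atoms accounts for the step, a question that a plain phenyl or a phenyl carrying the methoxy group alone could address, and it is equally open whether the step would hold with a different amine at the end of the chain. No measurement at hand gives a reason for the step.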